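The source may hold more compounds than are shown below. What is called first, only, known or untested is meant among the compounds shown, and "the series" means these compounds.

Among the measured compounds shown here, the three measured members share one core and differ at the amine nitrogen in a ring and at the benzamide substituent. Compound 1 `NC(=O)c1c(NC(=O)c2ccc(C(F)(F)F)cc2)sc2c1CCN(Cc1c(Cl)cccc1Cl)C2` gives 10600 nM in a functional assay on HL-60 cells (Homo sapiens) for antiproliferative activity, with a stated time of 24 h; on this read-out lower numbers stand for stronger inhibition and higher numbers for weaker inhibition. Compound 2 `NC(=O)c1c(NC(=O)c2ccc(C(F)(F)F)cc2)sc2c1CCN(Cc1ccc(Cl)cc1Cl)C2` gives 14900 nM in this assay, and compound 3 `Cc1ccc(C(=O)Nc2sc3c(c2C(N)=O)CCN(Cc2ccc(Cl)cc2Cl)C3)cc1` gives 19900 nM. Compound 2 stands second highest of the three numbers, nearest compound 3 and furthest from compound 1, with both gaps within the scatter. The step of a 1.4-fold higher number from compound 1 to compound 2 (0.15 log units; within the scatter) puts 2,4-dichlorophenyl in place of 2,6-dichlorophenyl on a saturated chain carbon bound to an amine nitrogen in a ring; the step of a 1.3-fold higher number from compound 2 to compound 3 (0.13 log units; within the scatter) puts methyl in place of trifluoromethyl on an aromatic carbon. Neither moved the number beyond the scatter.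

Compound 4 `NC(=O)c1c(NC(=O)c2ccc(C(F)(F)F)cc2)sc2c1CCN(C(=O)Nc1ccccc1Cl)C2` is not yet measured. It differs from compound 2 by (2-chlorophenyl)carbamoyl in place of 2,4-dichlorobenzyl on an amine nitrogen in a ring. For the measured compounds named here, no measured step covers an exchange of this kind: the one change made at the amine nitrogen in a ring, from compound 1 to compound 2, kept the dichlorophenyl and only moved its chlorines, and stayed within the scatter. With the three measured numbers lying close together, the working expectation for compound 4 is a number near theirs, with wide uncertainty in either direction. Compound 4 is expected to give about 16000 nM in this assay, between 5000 nM and 50000 nM. The step of a 1.1-fold higher number from compound 2 to compound 4 (0.03 log units; within the scatter) is expected to stay within the scatter.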

Compound 4, half-maximal inhibitory concentration: > 50000 nM
Compound 4 ended at the assay's limit; the forecaster's own chance of this, stated with the estimate: 25%; at least 3.1-fold (0.49 log units) between middle value and limit.
By their numbers in this assay, from the lowest: compounds 1, 2 and 3 (each within the scatter of the next). At a limit, above all of these: compound 4.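

For compound 4 the reading in this assay is a limit and not a number: the limit of > 50000 nM in this assay, at which 1 of the 4 values shown sits.

This makes the amine nitrogen in a ring the first place in the series where a change reaches beyond the scatter, with (2-chlorophenyl)carbamoyl entering in both new steps (an at least 3.3-fold higher number from compound 2 to compound 4 (0.52 log units; beyond the scatter); an at least 4.7-fold higher number from compound 1 to compound 4 (0.67 log units; beyond the scatter)). Moving the chlorines on the benzyl group left the number within the scatter (a 1.4-fold higher number from compound 1 to compound 2 (0.15 log units; within the scatter)), so this position is not shown to be insensitive once the benzyl group itself is exchanged.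

The exchange changes several things at once: the entering group carries a double bond outside aromatic rings, a hydrogen-bond donor and a hydrogen-bond acceptor, and has one chlorine where the group leaving has two, and the compounds shown do not separate these features. On these data alone, a 2-chlorobenzyl group or a (2,4-dichlorophenyl)carbamoyl group on the same nitrogen would tell the loss of a chlorine apart from the exchange of the link, and the effect of the carbamoyl with methyl in place of trifluoromethyl on the benzamide remains open.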